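A few compounds are considered here, and "the series" means these few. Any claim that something is new, unique, unknown or untested is made for them only; others in the source may bear on it.

Measured so far:
Compound 1, `O=C(NC(=S)NNc1ncnc2ccccc12)c1ccc(C(F)(F)F)cc1`: in a functional assay on GLC82 cells (Homo sapiens) for cytotoxicity, read by MTT assay, with a stated time of 72 h (a lower number here means a stronger inhibitor, a higher number a weaker inhibitor), compound 1 gives 12200 nM.
Compound 2, `COc1cc2ncnc(NNC(=S)NC(=O)c3ccccc3)c2cc1OC`: in this assay compound 2 gives 6550 nM.

Compound 1 holds the higher of these two numbers, yet the gap to compound 2 lies within the usual scatter of repeated measurements, so the two compounds cannot be told apart on this evidence. The two also differ in several places at once, so nothing about a single structural change can be read from them.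

Compound 3, `O=C(NC(=S)NNc1ncnc2ccccc12)c1ccc(F)cc1`, differs from compound 1 in one place: fluoro in place of trifluoromethyl on an aromatic carbon. For the measured compounds named here, no measured pair shows what this particular swap does in this assay, so the expectation rests on compound 1 alone. The step from compound 1 to compound 3 is expected to be small, a 1.0-fold lower number from compound 1 to compound 3 (0.01 log units; within the scatter), in no clear direction and not beyond the scatter. Compound 3 is therefore estimated at 12000 nM, with a range from 4000 nM to 36000 nM.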

Compound 3, half-maximal inhibitory concentration: 6070 nM
The estimate for compound 3 lay 2.0-fold (0.30 log units) above the measured number; the range from low to high includes it.
By their numbers in this assay, from the lowest: compounds 3, 2 and 1 (each within the scatter of the next).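

For the compounds shown here, this is the first comparison here that changes only one place, and fluoro in place of trifluoromethyl gives a 2.0-fold lower number from compound 1 to compound 3 (0.30 log units; within the scatter) in this assay. On this evidence, replacing a group of 4 heavy atoms with one of 1 heavy atom on this aromatic carbon, para to a large group, has no effect that can be told apart from the scatter of repeated measurements. Nothing measured here offers an explanation for this result.

Both groups tested at this position contain fluorine and have no hydrogen-bond donors or acceptors, so the compounds shown do not reveal what an amine or a carboxylic acid would do there. From the compounds shown here alone, it also remains open whether the same swap would give a similar result on the core of compound 2.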